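Ester in place of ether on the chromone series

This account rests on a few compounds, and the source may have more. Where it says the series, first, only, none or still open, it means among the compounds named here.

Measured so far:
compound 1 `CC(C)COc1ccc2oc(/C=C/[S+](C)[O-])cc(=O)c2c1` — 5000 nM
compound 2 `CC(C)Oc1ccc2oc(/C=C/[S+](C)[O-])cc(=O)c2c1` — 8000 nM

In a functional assay on DLD-1 cells (Homo sapiens) for cytotoxicity, with a stated time of 48 h (on this read-out higher numbers stand for weaker inhibition and lower numbers for stronger inhibition), compound 1 gives the lower of the two numbers, but the step of a 1.6-fold higher number from compound 1 to compound 2 (0.20 log units; within the scatter) lies within the scatter, so the two compounds cannot be ranked against each other. Compound 3 `C[S+]([O-])/C=C/c1cc(=O)c2cc(OC(=O)C(C)(C)C)ccc2o1` is not yet measured. It differs from compound 1 by (tert-butyl)carbonyl in place of isobutyl on an oxygen on an aromatic ring; the same difference, cut one bond further out, reads isobutoxy to ((tert-butyl)carbonyl)oxy.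

Among the compounds with values here, the only measured step, a 1.6-fold higher number from compound 1 to compound 2 (0.20 log units; within the scatter), exchanges one alkyl group for another on the same oxygen and shows no movement beyond the scatter. Within the data shown here, the change to compound 3 introduces a (tert-butyl)carbonyl with its own hydrogen-bond acceptor, which no measured pair covers, so the data give no direction. The step is therefore expected to be a 1.3-fold higher number from compound 1 to compound 3 (0.11 log units; within the scatter), with wide uncertainty. Compound 3 is estimated at 6500 nM, in the range 2500 nM to 16000 nM in this assay.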

Compound 3, half-maximal inhibitory concentration: 8000 nM
For compound 3 the middle estimate is 1.2-fold (0.09 log units) below the measured one; low and high end bracket the measured number.
By their numbers in this assay, from the lowest: compounds 1, 2 and 3 (each within the scatter of the next).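

In this assay the ester on this oxygen reads a 1.6-fold higher number from compound 1 to compound 3 (0.20 log units; within the scatter) and no change at the digits printed from compound 2 to compound 3 (within the scatter), so both steps stay inside the scatter. Within the data shown here, earlier, only one alkyl group had been exchanged for another; this result extends the flat reading to a (tert-butyl)carbonyl, which brings a carbonyl and a hydrogen-bond acceptor to the same place without a step beyond the scatter. No accompanying measurement bears on this result.

Still open, from the compounds shown here alone, is whether any group on this oxygen can move the number beyond the scatter, for instance a longer chain, an amine-bearing chain or a carboxylic acid. All three compounds share the rest of the core, so these notes say nothing about changes elsewhere on it.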